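The source may report more compounds than this note shows. Statements on the series, on what has been measured and on what is new or still open speak of the compounds shown alone.

Measured so far in a functional assay on B16-F10 cells (Mus musculus) for inhibition, read by MTT assay, with a stated time of 72 h; a higher number here means a weaker inhibitor, a lower number a stronger inhibitor:

compound 1 `CC(C)c1ccc(-c2nc(SCc3cn(CC(=O)NC(=O)Nc4ccccn4)nn3)nc(Nc3cccc(Cl)c3)c2C#N)cc1` — compound 1 gives 1130 nM
compound 2 `CC(C)c1ccc(-c2nc(SCc3cn(CC(=O)NC(=O)Nc4ccccn4)nn3)nc(Nc3ccccc3F)c2C#N)cc1` — compound 2 gives 8380 nM
compound 3 `Cc1ccccc1Nc1nc(SCc2cn(CC(=O)NC(=O)Nc3ccccn3)nn2)nc(-c2ccc(C(C)C)cc2)c1C#N` — compound 3 gives 18600 nM

Compound 2 holds the second highest of the three numbers in this assay: compound 3 lies nearest, at a 2.2-fold higher number from compound 2 to compound 3 (0.35 log units; beyond the scatter), and compound 1 lies furthest, at a 7.4-fold higher number from compound 1 to compound 2 (0.87 log units; beyond the scatter) read the other way.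

The next compound, compound 4 `Cc1cccc(Nc2nc(SCc3cn(CC(=O)NC(=O)Nc4ccccn4)nn3)nc(-c3ccc(C(C)C)cc3)c2C#N)c1`, carries 3-methylphenyl in place of 2-fluorophenyl on a nitrogen on an aromatic ring.

Two of the measured steps bear on this change. The swap of fluoro for methyl at the same ring position, a 2.2-fold higher number from compound 2 to compound 3 (0.35 log units; beyond the scatter), was a modest loss. The move of the substituent from the 2-position to the 3-position has no direct comparison, but the two 3-substituted and 2-substituted pairs that exist, a 7.4-fold higher number from compound 1 to compound 2 (0.87 log units; beyond the scatter) and a 16-fold higher number from compound 1 to compound 3 (1.22 log units; beyond the scatter), both show the 3-chlorophenyl compound 1 as clearly the strongest of the set. Compound 4 pairs a methyl, which cost in one step, with the 3-position, which gained in two. The net expectation in this assay is therefore a gain from compound 2, expected at a 2.8-fold lower number from compound 2 to compound 4 (0.45 log units; beyond the scatter), though a methyl at the 3-position has not been measured and the range is wide. Compound 4 is estimated at 3000 nM, with a likely range from 900 nM to 10000 nM.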

Compound 4, half-maximal inhibitory concentration: 1650 nM
Beside the measured number, compound 4's estimate is 1.8-fold (0.26 log units) above it; low and high end bracket the measured number.
By their numbers in this assay, from the lowest: compounds 1 and 4 (each within the scatter of the next); then compound 2; then compound 3.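

Working notes: in this assay, the swap of 2-methylphenyl for 3-methylphenyl on a nitrogen on an aromatic ring gives an 11-fold lower number from compound 3 to compound 4 (1.05 log units; beyond the scatter) and is the only pair here in which the same substituent changes ring position, so the position effect no longer has to be inferred across different groups. The step of a 5.1-fold lower number from compound 2 to compound 4 (0.71 log units; beyond the scatter) points the same way, although it changes both the substituent and its ring position and so cannot separate the two. The step of a 1.5-fold higher number from compound 1 to compound 4 (0.16 log units; within the scatter) means that methyl and chloro cannot be told apart on the 3-substituted phenyl, so the standing of compound 1 is not specific to chloro, and among these four compounds, both 3-substituted members, compound 1 and compound 4, have lower numbers than both 2-substituted members, compound 2 and compound 3, with none going against this split.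

Still open, from the compounds shown here alone, is whether 3-fluorophenyl, 2-chlorophenyl, 3-methoxyphenyl or unsubstituted phenyl would fit the same split. Nothing available explains why the 3-substituted compounds have the lower numbers.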